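Formyl to carbamoylcarbonyl in a calpain-1 series

The compounds below may be only part of what the source reports. "The series", "measured", "known", "first", "only" and "open" are said of these compounds alone.

Going by the values given here, compound 1 `CC(C)C[C@@H](C=O)NC(=O)[C@@H](NS(=O)(=O)c1ccc(/N=N/c2ccccc2)cc1)C(C)C` carries a formyl group and is the stronger of the two measured members: in an assay on cells (Erythrocyte) for inhibition of Calpain-1 catalytic subunit (Sus scrofa), using a Dixon plot (a lower number here means a stronger inhibitor, a higher number a weaker inhibitor), compound 1 gives 18 nM. Compound 2 `CC(C)C[C@@H](C=O)NC(=O)[C@@H]1CCCN1S(=O)(=O)c1ccc(/N=N/c2ccccc2)cc1` gives 273 nM in this assay; the gap between compound 1 and compound 2 lies beyond the scatter, so compound 1 holds the lowest number of the pair.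

Compound 3 `CC(C)C[C@H](NC(=O)[C@@H](NS(=O)(=O)c1ccc(/N=N/c2ccccc2)cc1)C(C)C)C(=O)C(N)=O` has not been measured. It differs from compound 1 in one place: carbamoyl in place of hydrogen on a carbonyl carbon. Among the compounds with values here, the exchange of the formyl group for a carbamoylcarbonyl group appears in no measured pair of the series, so the size of the step rests on no directly comparable numbers. The expectation for compound 3 is a moderate rise in number, that is a somewhat weaker inhibitor, with the step of a 2.8-fold higher number from compound 1 to compound 3 (0.44 log units; beyond the scatter) expected to reach only slightly beyond the scatter. For compound 3 in this assay the estimate is 50 nM, with a range from 12 nM to 250 nM.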

Compound 3, inhibition constant: 16 nM
Compound 3: middle estimate off by 3.1-fold (0.49 log units), on the high side, within the range that was stated.
By their numbers in this assay, from the lowest: compounds 3 and 1 (each within the scatter of the next); then compound 2.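

In this assay the exchange of formyl for carbamoylcarbonyl, with carbamoyl in place of hydrogen on a carbonyl carbon, comes out as a 1.1-fold lower number from compound 1 to compound 3 (0.05 log units; within the scatter) and leaves compound 3 and compound 1 indistinguishable. Going by these compounds alone, this is the first read-out of any change at this position: on the core of compound 1, the hydrogen on this carbonyl carbon can give way to carbamoyl, with its 3 heavy atoms, without a step beyond the scatter. No measurement at hand bears on why the two groups read alike.

The compounds shown leave open whether the same exchange also reads within the scatter on the core of compound 2, which gives 273 nM with the formyl group. They also leave open what a carboxylic acid, a methyl ester or a methylamide would give in place of the carbamoyl on the same carbonyl carbon, and so whether the amide nitrogen of the carbamoyl has any bearing on the number.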